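The compounds below may be only part of what the source reports. "The series", "measured", "known", "first", "only" and "open" are said of these compounds alone.

In a functional assay on a cell-free system (Platelet, plasma, Homo sapiens) for inhibition (on this read-out higher numbers stand for weaker inhibition and lower numbers for stronger inhibition), compound 1 `Cc1ccc(N(CCN2CCC(OCC(=O)O)CC2)C(=O)c2cccc(F)c2)cc1` gives 160 nM and compound 2 `Cc1ccc(N(CCN2CCC(OCC(=O)O)CC2)C(=O)c2cccc(Cl)c2)cc1` gives 100 nM. Going by the values given here, these are the only two numbers so far, and a 1.6-fold lower number from compound 1 to compound 2 (0.20 log units; within the scatter) shows that they cannot be told apart, so compound 2 stands level with compound 1. Compound 3 `COc1cc(OC)cc(C(=O)N(CCN2CCC(OCC(=O)O)CC2)c2ccc(C)cc2)c1` keeps the shared core and differs at one place, with 3,5-dimethoxyphenyl in place of 3-chlorophenyl on a carbonyl carbon. Among the compounds with values here, only one measured step touches this aromatic group, and it is a much smaller swap, so it offers limited guidance. Within the data shown here, no measured compound carries the 3,5-dimethoxyphenyl group. Among the measured compounds shown here, with only that step from compound 1 to go on, no shift beyond the scatter is expected in this assay, and no direction is favoured. The expected step is a 1.5-fold higher number from compound 2 to compound 3 (0.18 log units; within the scatter). For compound 3 the estimate is 150 nM, with an expected range of 50 nM to 450 nM.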

Compound 3, half-maximal inhibitory concentration: 530 nM
Estimate against measurement, compound 3: 3.5-fold (0.55 log units) below; the whole stated range lies below it.
By their numbers in this assay, from the lowest: compounds 2 and 1 (each within the scatter of the next); then compound 3.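

In this assay this position on a carbonyl carbon proves sensitive to the aromatic group it carries: 3,5-dimethoxyphenyl in place of 3-chlorophenyl gives a 5.3-fold higher number from compound 2 to compound 3 (0.72 log units; beyond the scatter) and 3,5-dimethoxyphenyl in place of 3-fluorophenyl gives a 3.3-fold higher number from compound 1 to compound 3 (0.52 log units; beyond the scatter) in the same direction. The earlier swap of fluoro for chloro stayed within the scatter, so this larger change is the first shown here to weaken inhibition beyond it. Nothing measured here explains the weakening, and the data cannot separate the two added methoxy groups from any other part of the change.

The compounds shown leave open whether a single methoxy group on the ring would give the same result as the pair. They also leave open how an amine or a carboxylic acid on this aromatic ring would fare.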